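Homologation of the terminal hydroxy on the triple-bonded chain

The source may report more compounds than this note shows. Statements on the series, on what has been measured and on what is new or still open speak of the compounds shown alone.

Measured so far:
compound 1 `Cc1ccc(S(=O)(=O)OCCC#Cc2cn([C@H]3C[C@H](O)[C@@H](CO)O3)c(=O)[nH]c2=O)cc1` — in a functional assay on L1210 cells (Mus musculus) (on this read-out higher numbers stand for weaker inhibition and lower numbers for stronger inhibition), compound 1 gives only a limit, > 200 ug/mL.
compound 2 `O=c1[nH]c(=O)n([C@H]2C[C@H](O)[C@@H](CO)O2)cc1C#CCO` — in this assay compound 2 gives only a limit, > 1000 ug/mL.

Neither value is a measured number; both are limits of the assay. Compound 2 sits at the limit of > 1000 ug/mL in this assay, at which 1 of the 2 values shown sits. The other value sits at the limit of > 200 ug/mL in this assay, at which 1 of the 2 values shown sits. Among the measured compounds shown here, no step between measured compounds can be drawn from two limits, and no effect of any group has been measured here.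

Compound 3 `O=c1[nH]c(=O)n([C@H]2C[C@H](O)[C@@H](CO)O2)cc1C#CCCCO` is the next member. It differs from compound 2 by 2-hydroxyethyl in place of hydroxy on a saturated chain carbon bound to a triple-bonded carbon, placed on a saturated chain carbon bound to a triple-bonded carbon. With compound 2 already at a limit in this assay, the step to compound 3 is expected to be none beyond the scatter, a number no higher from compound 2 to compound 3 (the limit leaves the size open), with compound 3 expected to return a limit again. Compound 3 is thus expected at about 1000 ug/mL, within 300 ug/mL to 3000 ug/mL.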

Compound 3, concentration for 50% inhibition: 280 ug/mL
Estimate against measurement, compound 3: 3.6-fold (0.55 log units) above; the measured number lies below the stated range.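

In this assay, among the compounds shown here, compound 3 gives 280 ug/mL, the first value that is a number and not a limit. The chain on the triple-bonded carbon is therefore a place where a change can be read: 2-hydroxyethyl in place of hydroxy on a saturated chain carbon bound to a triple-bonded carbon gives an at least 3.5-fold lower number from compound 2 to compound 3 (0.55 log units; beyond the scatter), and the chain ends in a hydroxy in both compounds. The full size of this step stays open, because compound 2 stands only at a limit: the limit of > 1000 ug/mL in this assay, at which 1 of the 3 values shown sits.

Going by these compounds, it remains open whether a longer chain ending in hydroxy would lower the number further or raise it again. On these data alone, it is also open whether the terminal hydroxy matters at all, a question that an amine or a carboxylic acid at the chain end would address.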